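The source may report more compounds than this note shows. Statements on the series, on what has been measured and on what is new or still open speak of the compounds shown alone.

Measured so far in a functional assay on HEK293 cells for antagonist activity at Voltage-dependent L-type calcium channel subunit alpha-1C (Oryctolagus cuniculus), read by FLIPR; on this read-out higher numbers stand for weaker inhibition and lower numbers for stronger inhibition:
- compound 1 `C#CCCOC(=O)C1=C(C)NC(C)=C(C(=O)OC)C1c1cccc([N+](=O)[O-])c1` gives 31 nM
- compound 2 `COC(=O)C1=C(C)NC(C)=C(C(=O)OCC(C)[N+](=O)[O-])C1c1cccc([N+](=O)[O-])c1` gives 108 nM
- compound 3 `COC(=O)C1=C(C)NC(C)=C(C(=O)OCc2ccco2)C1c1cccc([N+](=O)[O-])c1` gives 20 nM

Compound 3 shows the lowest of these three numbers, although its gap to compound 1 is small: a 1.6-fold lower number from compound 1 to compound 3 (0.19 log units; within the scatter), which is within the usual scatter. The gap to compound 2 is larger, a 5.4-fold lower number from compound 2 to compound 3 (0.73 log units; beyond the scatter). All three differ only in the group on a saturated chain carbon bound to an oxygen next to a carbonyl group.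

Compound 4 `COC(=O)C1=C(C)NC(C)=C(C(=O)OCCCOc2ccccc2)C1c1cccc([N+](=O)[O-])c1` changes that same position: 2-phenoxyethyl in place of furan-2-yl on a saturated chain carbon bound to an oxygen next to a carbonyl group. Going by the values given here, no measured step involves a phenoxy group, so the guidance is indirect. Compounds 1 and 3 show that two rather different groups at this position give numbers within the scatter of each other, while compound 2 shows that a change there can matter: a 3.5-fold higher number from compound 1 to compound 2 (0.54 log units; beyond the scatter). A larger group carrying one six-membered aromatic ring is expected to behave more like compound 1 than compound 2, so the expected step is a 1.5-fold higher number from compound 3 to compound 4 (0.18 log units; within the scatter), near the scatter. Compound 4 is therefore estimated at 30 nM, in the range 10 nM to 100 nM.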

Compound 4, half-maximal inhibitory concentration: 9 nM
Compound 4: middle estimate off by 3.3-fold (0.52 log units), on the high side, outside the stated range (below it).
By their numbers in this assay, from the lowest: compound 4; then compounds 3 and 1 (each within the scatter of the next); then compound 2.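

Replacing (furan-2-yl)methyl with 3-phenoxypropyl lowers the number further (a 2.2-fold lower number from compound 3 to compound 4 (0.35 log units; beyond the scatter)), so this position can hold a longer chain ending in a six-membered aromatic ring without any loss of inhibition. Compound 4 also stands clear of the other two compounds, with steps (a 3.4-fold lower number from compound 1 to compound 4 (0.54 log units; beyond the scatter)) and (a 12-fold lower number from compound 2 to compound 4 (1.08 log units; beyond the scatter)), and the second of these is the widest gap in the set so far, showing that this one position alone can move the number a long way. Nothing measured here accounts for these steps.

Going by these compounds, it stays open whether the benzene ring, the ether oxygen or the chain length matters most, as the four compounds do not separate these parts. A 3-phenylpropyl group, a longer chain ending in phenoxy, or a chain ending in an amine would each test a different part of that question.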